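The source may report more compounds than this note shows. Statements on the series, on what has been measured and on what is new or still open speak of the compounds shown alone.

Measured in an assay on HEK293 cells for antagonist activity at transient receptor potential cation channel subfamily V member 3 (Homo sapiens), read by FLIPR and calcium flux; on this read-out higher numbers stand for weaker inhibition and lower numbers for stronger inhibition:
compound 1, `O[C@H](c1ccccn1)[C@]1(c2ccc(Cl)c(Cl)c2)CCCO1` — 470 nM
compound 2, `CN1CC(c2ccc(C(F)(F)F)cc2)(C(O)c2ccccn2)C1` — 6630 nM
compound 3, `O[C@H](c1ccccn1)[C@]1(c2cc(C(F)(F)F)ccn2)C[C@@H](O)C1` — 320 nM

Among these three numbers compound 1 stands second highest. Its nearest neighbour is compound 3, whose value lies within the scatter of the value of compound 1, so the two cannot be told apart on this read-out. Compound 2 stands furthest from compound 1, with the higher number of the pair and a gap beyond the scatter. Within the data shown here, no two of the measured compounds differ in a single place, so there is no measured step to guide the next change.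

Compound 4, `O[C@H](c1ccccn1)[C@@]1(c2ccc(Cl)c(Cl)c2)CCCO1`, has not yet been measured in this assay. the two compounds have the same atoms and bonds and differ only in configuration as drawn: 1 of 2 stereo elements differ; a stereocentre at a saturated ring carbon is drawn R in compound 1 and S in compound 4 Nothing enters and nothing leaves; only the configuration at one saturated ring carbon is inverted. Among the measured compounds shown here, the measured set holds no pair differing only in configuration, so the data give no measured size for such a step. A change of configuration at a ring carbon is expected to matter, but the direction cannot be read from what has been measured; the estimate leans toward a weaker value and carries a wide range. The step from compound 1 to compound 4 is expected to be a 2.3-fold higher number from compound 1 to compound 4 (0.37 log units; beyond the scatter). Compound 4 is therefore estimated at 1100 nM, with a range from 200 nM to 6000 nM.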

Compound 4, antagonist equilibrium constant: 43 nM
The estimate for compound 4 lay 26-fold (1.41 log units) above the measured number; the whole stated range lies above it.
By their numbers in this assay, from the lowest: compound 4; then compounds 3 and 1 (each within the scatter of the next); then compound 2.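

Until this pair, the set offered no measured size for a change of configuration alone, so the weight of this saturated ring carbon was unknown. In this assay, inverting this stereocentre from R to S gives an 11-fold lower number from compound 1 to compound 4 (1.04 log units; beyond the scatter), a large step with nothing entering and nothing leaving. The step can be assigned to this one stereocentre alone, because no other difference separates the pair: the fact that compounds 1 and 4 differ only in the configuration as drawn

Going by these compounds, the second stereo element is drawn the same in both compounds, so the effect of inverting it remains open, as does whether the S configuration at the ring carbon would give a similar step on the different cores of compound 2 and compound 3. On these data alone, it is also open whether the two chlorine atoms can be exchanged for a nitrile or an amine while keeping a number close to that of compound 4, 43 nM.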